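The compounds below may be only part of what the source reports. "The series", "measured", "known", "first", "only" and "open" are said of these compounds alone.

Two compounds have been measured in a functional assay on 786-0 cells (Homo sapiens) for inhibition, read by sulforhodamine B assay, with a stated time of 48 h; on this read-out lower numbers stand for stronger inhibition of growth and higher numbers for weaker inhibition of growth:

Compound 1 `Nc1cc(N)c2nc(-c3ccccc3)c(Oc3ccc(Cl)c(Cl)c3)nc2c1`: 44700 nM
Compound 2 `COc1ccc(CNc2nc3cc(N)cc(N)c3nc2-c2ccccc2)cc1`: 41700 nM

Compound 1 and compound 2 give numbers that lie within the usual scatter of each other, so neither stands apart in this assay. Compound 3 `Nc1cc(N)c2nc(-c3ccccc3)c(Oc3ccc(F)cc3)nc2c1` differs from compound 1 by 4-fluorophenyl in place of 3,4-dichlorophenyl on an oxygen on an aromatic ring. For the measured compounds named here, no measured pair shows what this kind of change does here, so the step from compound 1 to compound 3 in this assay is expected to stay within the scatter, with no clear direction: a 1.1-fold higher number from compound 1 to compound 3 (0.05 log units; within the scatter). Compound 3 is therefore estimated at 50000 nM, likely between 20000 nM and 110000 nM.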

Compound 3, concentration for total growth inhibition: 34700 nM
For compound 3 the middle estimate is 1.4-fold (0.16 log units) above the measured one; the range from low to high includes it.
By their numbers in this assay, from the lowest: compounds 3, 2 and 1 (each within the scatter of the next).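

In this assay, putting 4-fluorophenyl in place of 3,4-dichlorophenyl on the oxygen gives a 1.3-fold lower number from compound 1 to compound 3 (0.11 log units; within the scatter). This first pair at this position shows that this exchange of one substituted phenyl ring for another, with both chlorines gone and a fluorine added, leaves the growth read-out within the scatter. Nothing available explains why the two rings read alike. Still open, as far as these compounds go, is whether a phenyl ring carrying an amine or a carboxylic acid, or a longer chain on that oxygen in place of the ring, would shift the number beyond the scatter.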